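A few compounds are considered here, and "the series" means these few. Any claim that something is new, unique, unknown or untested is made for them only; others in the source may bear on it.

Measured so far:
compound 1 `Cc1c(Cc2c(F)cccc2F)nc(SCc2ccccc2)[nH]c1=O`: > 70000 nM
compound 2 `COc1ccc(C(=O)CSc2nc(Cc3cccc4ccccc34)c(C(C)C)c(=O)[nH]2)cc1`: 203000 nM

Both compounds were tested in an ADME assay on MT4 cells (Homo sapiens) for cytotoxicity, read by MTT assay; a higher number here means that more compound is tolerated, a lower number that less compound is tolerated. Compound 1 gives > 70000 nM, which is a limit of the assay and not a number. Among the compounds with values here, compound 2, at 203000 nM, holds the only actual number, so the two compounds cannot be ranked against each other.

Compound 3 `COc1ccc(C(=O)CSc2nc(Cc3c(Cl)cccc3Cl)c(C(C)C)c(=O)[nH]2)cc1` has not yet been measured. It differs from compound 2 in one place: 2,6-dichlorophenyl in place of naphthalen-1-yl on a saturated chain carbon bound to an aromatic carbon. Read one bond further out, this is (naphthalen-1-yl)methyl to 2,6-dichlorobenzyl.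

Within the data shown here, no measured pair shows what such a change does in this assay, so no step beyond the usual scatter is expected, in either direction. The estimated change is a 1.3-fold lower number from compound 2 to compound 3 (0.10 log units; within the scatter). The assay may again report only a limit. For compound 3 the expected value is 160000 nM, with an estimated range of 60000 nM to 350000 nM.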

Compound 3, half-maximal cytotoxic concentration: > 14000 nM
Compound 3: no number, only a limit (the forecaster's own chance of this, stated with the estimate: 40%); the middle value does not contradict the limit.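

In this assay compound 3 gives > 14000 nM, which is a limit of the assay and not a number. Within the data shown here, no step from compound 2 to compound 3 can therefore be read. As far as these compounds go, whether 2,6-dichlorophenyl in place of naphthalen-1-yl changes how much compound is tolerated, and in which direction, stays open.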